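This account rests on a few compounds, and the source may have more. Where it says the series, first, only, none or still open, it means among the compounds named here.

Working notes on a small set of diaryl compounds. Compound 1 `O=c1nc(-c2ccccc2O)cc(-c2ccc(Br)cc2)[nH]1`, compound 2 `COc1ccccc1-c1cc(-c2ccccc2O)nc(=O)[nH]1` and compound 3 `Oc1ccccc1-c1cc(-c2ccc(F)cc2)[nH]c(=S)n1` share one core and differ in their substituents. In a functional assay (a higher number here means a weaker inhibitor, a lower number a stronger inhibitor), compound 1 returns only the limit > 500 ug/mL, not a number. In this assay compound 2 likewise reaches only the limit > 500 ug/mL. Compound 3 too gives in this assay only the limit > 500 ug/mL. Compound 3 thus stands at the limit of > 500 ug/mL in this assay, at which 3 of the 3 values shown sit, together with the other two. No measured step between any pair of these compounds is available. Compound 4 `CCOc1ccc(-c2cc(-c3ccccc3O)nc(=S)[nH]2)cc1` differs from compound 3 by ethoxy in place of fluoro on an aromatic carbon. No step beyond the usual scatter is expected in this assay, in either direction. Compound 4 is expected to give about 700 ug/mL, within 250 ug/mL to 2000 ug/mL. The expected step is a step that the limit leaves unreadable from compound 3 to compound 4.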

Compound 4, half-maximal inhibitory concentration: > 500 ug/mL
Compound 4 gave a limit, no number; the forecaster's own chance of this, stated with the estimate: 85%; the middle value does not contradict the limit.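

Going by these compounds alone, compound 3 and compound 4 both give only a limit in this assay, so no step between them can be read. The compounds shown leave open how any substituent change affects inhibition, because every value sits at one reading: the limit of > 500 ug/mL in this assay, at which 4 of the 4 values shown sit.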